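The source may report more compounds than this note shows. Statements on the series, on what has been measured and on what is new or still open speak of the compounds shown alone.

Compound 1 `COc1ccc(C2C(C#N)=C(N)N(c3cc(OC)c(OC)c(OC)c3)C3=C2C(=O)CC(C)(C)C3)cc1` is tested in a functional assay on Ehrlich cells (Mus musculus) for cytotoxicity, tested at 25 ug/mL (on this read-out lower numbers stand for a weaker effect and higher numbers for a stronger effect at the one concentration tested), where compound 1 gives 1%. Among the two numbers available, compound 1 stands lowest; the nearest is compound 2 `COc1cc(N2C(N)=C(C#N)C(c3c(O)ccc4ccccc34)C3=C2CC(C)(C)CC3=O)cc(OC)c1OC`, which in this assay gives 10%. For the measured compounds named here, the single recorded step between them, a number 9 percentage points higher from compound 1 to compound 2 (within the scatter), exchanges one aromatic group for another on the saturated ring carbon and stays within the scatter of the measurement.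

Compound 3 `COc1cc(N2C(N)=C(C#N)C(c3cccs3)C3=C2CC(C)(C)CC3=O)cc(OC)c1OC` has not yet been measured in this assay. Relative to compound 1 it differs in one place: thiophen-2-yl in place of 4-methoxyphenyl on a saturated ring carbon.

Going by the values given here, the only measured step that bears on this change is the one from compound 1 to compound 2, since it also replaces the group on the saturated ring carbon; that step was a number 9 percentage points higher from compound 1 to compound 2 (within the scatter) and did not reach beyond the scatter. Nothing in the data suggests that the change at this position moves the read-out in either direction. Compound 3 is therefore expected to show a step of a number 4 percentage points higher from compound 1 to compound 3 (within the scatter), that is, no change beyond the scatter. The estimate for compound 3 in this assay is 5%, with a range from 0% to 20%.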

Compound 3, a percentage reported as activity, at one concentration (the size of the read-out at that concentration, not a potency): 10%
Compound 3: middle estimate off by 5 percentage points, on the low side; low and high end bracket the measured number.
By their numbers in this assay, from the lowest: compounds 1, 2 and 3 (each within the scatter of the next).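

With thiophen-2-yl in place of 4-methoxyphenyl on the saturated ring carbon, the compounds show a number 9 percentage points higher from compound 1 to compound 3 (within the scatter) in this assay. This adds a five-membered aromatic ring with one sulfur atom and only 5 heavy atoms to the two six-membered-ring aromatic groups seen so far, and the comparison with the 2-hydroxynaphthalen-1-yl group gives no change at the digits printed from compound 2 to compound 3 (within the scatter), so all three aromatic groups on this carbon now lie within the scatter of one another in this assay. No measurement is available that explains this outcome.

The compounds shown leave open whether a group without an aromatic ring on this carbon, such as cyclohexyl or a longer alkyl chain, or an aromatic ring carrying a carboxylic acid or a dimethylamino group, would move the read-out beyond the scatter. Going by these compounds, all three compounds also carry the same 3,4,5-trimethoxyphenyl group, so what a different group at that place, such as a plain phenyl or a 4-chlorophenyl, would do remains open.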